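The source may report more compounds than this note shows. Statements on the series, on what has been measured and on what is new or still open speak of the compounds shown alone.

Of the compounds shown here, three have been measured in an assay on isolated protein for inhibition of Rho-associated protein kinase 2 (Homo sapiens), read by a luciferase reporter; on this read-out lower numbers stand for stronger inhibition and higher numbers for weaker inhibition. Compound 1 `NCC(=O)Nc1cc2cc[nH]c(=O)c2cc1Cl` gives 120 nM. Compound 2 `O=C(Nc1cc2cc[nH]c(=O)c2cc1Cl)C1CNCC1c1ccccn1` gives 14 nM. Compound 3 `CC(C)(C)c1cccc(C2CNCC2C(=O)Nc2cc3cc[nH]c(=O)c3cc2Cl)c1` gives 11 nM. Among these three numbers compound 2 stands second highest; its nearest neighbour is compound 3, with a 1.3-fold lower number from compound 2 to compound 3 (0.10 log units; within the scatter), while compound 1 sits furthest off, with a higher number beyond the scatter.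

Compound 4 `O=C(Nc1cc2cc[nH]c(=O)c2cc1Cl)C1CNCC1c1cccc(Br)c1` is not yet measured. It differs from compound 2 in one place: 3-bromophenyl in place of pyridin-2-yl on a saturated ring carbon. Going by the values given here, the only measured step that bears on this change is the one from compound 2 to compound 3, which likewise replaced the pyridin-2-yl on that saturated ring carbon by a substituted phenyl, 3-(tert-butyl)phenyl, and moved the number only within the scatter. On that single precedent no step beyond the scatter is expected in this assay for compound 4, in either direction, and the step of a 1.1-fold lower number from compound 2 to compound 4 (0.03 log units; within the scatter) implied by the estimate is accordingly small. Compound 4 is expected at 13 nM, within a range of 6 nM to 30 nM. One precedent is a thin basis, so the range is kept wide.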

Compound 4, half-maximal inhibitory concentration: 2 nM
Beside the measured number, compound 4's estimate is 6.5-fold (0.81 log units) above it; the whole stated range lies above it.
By their numbers in this assay, from the lowest: compound 4; then compounds 3 and 2 (each within the scatter of the next); then compound 1.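

In this assay, the aromatic group on this saturated ring carbon now shows a real effect on the number: 3-bromophenyl in place of pyridin-2-yl gives a 7.0-fold lower number from compound 2 to compound 4 (0.85 log units; beyond the scatter), whereas 3-(tert-butyl)phenyl in the same place gave only a 1.3-fold lower number from compound 2 to compound 3 (0.10 log units; within the scatter). A phenyl ring at this carbon therefore does not set the number by itself, and the substituent on it matters: bromo in place of tert-butyl gives a 5.5-fold lower number from compound 3 to compound 4 (0.74 log units; beyond the scatter). Nothing available explains the size of either step.

Open, on these data alone, is whether unsubstituted phenyl, or chloro or methoxy in the place of bromo, would keep the number of compound 4. Also open, as far as these compounds go, is whether a methyl or acetyl group on the ring nitrogen of the five-membered ring would leave it unchanged.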